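The source may report more compounds than this note shows. Statements on the series, on what has been measured and on what is new or still open speak of the compounds shown alone.

Compound 1 `CC(=O)c1ccccc1OC(C)C1=NCCN1`: 0.65
Compound 2 `COc1ccccc1OC(C)C1=NCCN1`: 0.6

In an assay on CHO cells with Alpha-2C adrenergic receptor (Homo sapiens) as the target (a higher number here means a larger maximal response, a lower number a smaller maximal response), compound 2 gives the lower of the two numbers, though the gap to compound 1 is within the scatter: the step a number 0.050 lower from compound 1 to compound 2 (within the scatter) changed little. Compound 3 `C=COc1ccccc1OC(C)C1=NCCN1` differs from compound 2 in one place: vinyl in place of methyl on an oxygen on an aromatic ring. Going by the values given here, no measured step swaps a methyl for a vinyl on an oxygen on an aromatic ring, so none bears directly on this change; the single step known, a number 0.050 lower from compound 1 to compound 2 (within the scatter), stayed within the scatter. The step of no change at the digits printed from compound 2 to compound 3 (within the scatter) is therefore expected to stay within the scatter too. Compound 3 is estimated at 0.6, between 0.45 and 0.75.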

Compound 3, intrinsic activity: the largest response reached, as a fraction of the reference agonist's: 0.48
The estimate for compound 3 lay 0.12 above the measured number, within the range that was stated.
By their numbers in this assay, from the lowest: compound 3; then compounds 2 and 1 (each within the scatter of the next).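

In this assay, vinyl in place of methyl on the oxygen gives a number 0.12 lower from compound 2 to compound 3 (beyond the scatter) and so moves the maximal response beyond the scatter, which the earlier pair did not do. Vinyloxy in place of acetyl on the aromatic carbon also gives a number 0.17 lower from compound 1 to compound 3 (beyond the scatter) while methoxy in that place stayed within the scatter, so the choice of group here can matter. No measured evidence accounts for this drop. On these data alone, whether a longer chain, such as propyl, on the oxygen would lower the response further remains open, as does the effect of an amine on the aromatic carbon.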